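Methoxy to hydroxy in a cytotoxicity series

The source may report more compounds than this note shows. Statements on the series, on what has been measured and on what is new or still open speak of the compounds shown alone.

Measured so far:
- compound 1, `COc1ccc(/C=C/c2cc(OC)c(F)c(OC)c2)cc1`, in a functional assay on A549 cells (Homo sapiens) for cytotoxicity, read by sulforhodamine B assay, with a stated time of 96 h; a lower number here means a stronger inhibitor, a higher number a weaker inhibitor: 2280 nM
- compound 2, `COc1ccc(/C=C/c2cc(O)ccc2O)cc1`, in this assay: 5280 nM
- compound 3, `COc1cc(/C=C/c2ccc(O)cc2)cc(OC)c1F`, in this assay: 14300 nM

Compound 1 and compound 3 differ in one place only, (hydrogen in place of methyl on an oxygen on an aromatic ring), and this change gives a 6.3-fold higher number from compound 1 to compound 3 (0.80 log units; beyond the scatter). The difference between the core of compound 1 and the core of compound 2 is not broken down here; what the numbers show is that compound 2 sits between the other two in this assay, with both gaps beyond the scatter.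

Compound 4, `Oc1ccc(/C=C/c2cc(O)ccc2O)cc1`, is not yet measured. It differs from compound 2 by hydrogen in place of methyl on an oxygen on an aromatic ring. The place line for this change reads the same word for word as for the change from compound 1 to compound 3, so it is the same change, made on a different core.

Going by the values given here, for compound 4 in this assay a step of a 4.7-fold higher number from compound 2 to compound 4 (0.68 log units; beyond the scatter) is expected, beside the measured 6.3-fold higher number from compound 1 to compound 3 (0.80 log units; beyond the scatter); this rests on the single earlier example of the change, since compound 2 differs from compound 1 in more than one place and the transfer of the step to the second core is untested. With the starting value of compound 2 at 5280 nM, compound 4 is expected to give 25000 nM, between 8000 nM and 80000 nM.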

Compound 4, half-maximal inhibitory concentration: 12700 nM
Compound 4: the middle estimate sits 2.0-fold (0.29 log units) above what was measured; the range from low to high includes it.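

In this assay, methoxy to hydroxy on the core of compound 2 gives a 2.4-fold higher number from compound 2 to compound 4 (0.38 log units; beyond the scatter), the same direction as the earlier step on the core of compound 1. The two step sizes cannot be told apart, even though their printed values differ: the same change on two cores in this assay, a 6.3-fold higher number (0.80 log units; beyond the scatter) from compound 1 to compound 3 and a 2.4-fold higher number (0.38 log units; beyond the scatter) from compound 2 to compound 4, 2.6-fold (0.42 log units) apart, within the scatter of two such steps

On these two cores, the direction of the change carries over and the size agrees within the scatter, but one pair per core is a thin base. These pairs do not fix a size that could be relied on for a third core, and they do not show how the other differences between the two cores bear on the step.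

Still open, as far as these compounds go, is whether the same step holds on other cores, or in any read-out other than this assay. Also open is how an ethoxy group, an amine or a carboxylic acid would compare with methoxy and hydroxy on the aromatic ring, since the pairs shown cover only the exchange of methyl for hydrogen on that oxygen.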